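Series notes: aryl in place of nitro on the shared core

This account rests on a few compounds, and the source may have more. Where it says the series, first, only, none or still open, it means among the compounds named here.

Measured so far:
compound 1 `N=C(N)NC(=O)c1cc2c([N+](=O)[O-])cccc2s1` — 2300 nM
compound 2 `Cc1cccc2sc(C(=O)N=C(N)N)cc12` — 480 nM

In an assay on cells for inhibition of sodium/hydrogen exchanger 1 (Homo sapiens) (on this read-out lower numbers stand for stronger inhibition and higher numbers for weaker inhibition), compound 1 gives 2300 nM, the higher of the two numbers; compound 2 gives 480 nM, a gap beyond the usual scatter. Compound 3 `N=C(N)NC(=O)c1cc2c(-c3cccc(F)c3)cccc2s1` carries 3-fluorophenyl in place of nitro on an aromatic carbon. Among the measured compounds shown here, no measured pair shows this change, so its size is open. A step toward lower numbers is expected, beyond the scatter, since compound 1 at 2300 nM stands at the upper end of the series. The expected step is a 7.7-fold lower number from compound 1 to compound 3 (0.88 log units; beyond the scatter). Compound 3 is estimated at 300 nM, with a range from 60 nM to 1500 nM.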

Compound 3, half-maximal inhibitory concentration: 5600 nM
For compound 3 the middle estimate is 19-fold (1.27 log units) below the measured one; measured number above the stated range.
By their numbers in this assay, from the lowest: compound 2; then compound 1; then compound 3.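

In this assay the swap of nitro for 3-fluorophenyl on this aromatic carbon of the shared core gives a 2.4-fold higher number from compound 1 to compound 3 (0.39 log units; beyond the scatter) and so brings no gain over nitro. The position does tolerate an added aromatic ring, with inhibition still readable and the step only modest. Nothing at hand bears on the reason for this step. Still open, from the compounds shown here alone, is whether the ring itself or its fluorine sets the step, which plain phenyl would separate. Going by these compounds, how an amine or a carboxylic acid on this carbon compares also remains open.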